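The source may report more compounds than this note shows. Statements on the series, on what has been measured and on what is new or still open speak of the compounds shown alone.

In an ADME assay on HEp-2 cells (Homo sapiens) for cytotoxicity (a higher number here means that more compound is tolerated, a lower number that less compound is tolerated), compound 1 (`CC(C)CCn1c(Cn2c(=O)n(C(C)C)c3ccccc32)nc2cc(C(C)(C)N)ccc21`) gives 3270 nM and compound 2 (`CC(C)CCn1c(Cn2c(=O)n(C(C)C)c3ccccc32)nc2cc(-c3ncon3)ccc21`) gives 223000 nM, the higher of the two numbers. Compound 3 (`COC(=O)c1ccc2c(c1)nc(Cn1c(=O)n(C(C)C)c3ccccc31)n2CCC(C)C`) has methoxycarbonyl in place of 1,2,4-oxadiazol-3-yl on an aromatic carbon, the same position that differs between the two measured compounds: methoxycarbonyl in place of 1,2,4-oxadiazol-3-yl on an aromatic carbon. Among the measured compounds shown here, only one measured step bears on this change, a 68-fold higher number from compound 1 to compound 2 (1.83 log units; beyond the scatter), which is large and beyond the scatter. That step brought in the group that now leaves, but it started from 1-amino-1-methylethyl, so its size need not carry over. For the measured compounds named here, neither group in the new change has a net charge, and no measured pair links them directly. Only a small step in this assay is therefore expected, slightly downward if it can be seen at all. The expected step is a 1.5-fold lower number from compound 2 to compound 3 (0.17 log units; within the scatter), which would lie within the scatter. For compound 3 the estimated value is 150000 nM, with an expected range of 50000 nM to 350000 nM.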

Compound 3, half-maximal cytotoxic concentration: 33700 nM
Compound 3: the middle estimate sits 4.5-fold (0.65 log units) above what was measured; the measured number lies below the stated range.
By their numbers in this assay, from the lowest: compound 1; then compound 3; then compound 2.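

In this assay, the aromatic carbon that carries these groups turns out to respond to more than the loss of 1-amino-1-methylethyl: a change between two groups with no net charge, methoxycarbonyl in place of 1,2,4-oxadiazol-3-yl, gives a 6.6-fold lower number from compound 2 to compound 3 (0.82 log units; beyond the scatter) and so is not silent. Measured against 1-amino-1-methylethyl, the same methoxycarbonyl gives a 10-fold higher number from compound 1 to compound 3 (1.01 log units; beyond the scatter) and thus accounts for only part of the rise seen with 1,2,4-oxadiazol-3-yl, leaving all three groups separated by steps beyond the scatter. No measurement at hand accounts for these differences.

From the compounds shown here alone, whether a carboxylic acid or a primary amide on this aromatic carbon would fall nearer compound 1 or compound 2 stays open. So does whether this order of the three groups would hold with a different chain in place of the one shared by these compounds.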